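Replacing the Benzyl Group of a Compound with Low Inhibition in a Cell Growth Assay

The source may report more compounds than this note shows. Statements on the series, on what has been measured and on what is new or still open speak of the compounds shown alone.

Two compounds sharing a core, compound 1 `CC(C)=CCC/C(C)=C/CC1Cc2c(O)cc(=O)n(CCCO)c2CC1(C)C` and compound 2 `CC(C)=CCC1Cc2c(OCc3ccccc3)cc(=O)n(CCCO)c2CC1(C)C`, have been tested in a functional assay on PANC-1 cells (Homo sapiens) for inhibition, read by MTT assay, with a stated time of 24 h, tested at 10 uM; a lower number here means less inhibition, a higher number more inhibition at the concentration tested (going by the name of the read-out). In this assay compound 1 gives 0%, while compound 2 gives 11.1%, the higher of the two numbers and a gap beyond the usual scatter. Compound 3 `CC(C)=CCC1Cc2c(OC(=O)Nc3ccc(F)c(F)c3)cc(=O)n(CCCO)c2CC1(C)C` differs from compound 2 in a single place: (3,4-difluorophenyl)carbamoyl in place of benzyl on an oxygen on an aromatic ring. Among the compounds with values here, no measured pair here shows how a change of this kind plays out, so its direction is open. Because compound 2 stands at 11.1%, both known numbers are low, and a small rise or fall seems as plausible as no change beyond the scatter. The step expected in this assay is a number 3.9 percentage points higher from compound 2 to compound 3 (within the scatter). For compound 3 in this assay the estimated value is 15%, with a range from 0% to 35%.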

Compound 3, a percentage reported as inhibition, at one concentration (the size of the read-out at that concentration, not a potency): 0%
Compound 3: middle estimate off by 15 percentage points, on the high side; the range from low to high includes it.
By their numbers in this assay, from the lowest: compounds 1 and 3 (each within the scatter of the next); then compound 2.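

Within the data shown here, the change from benzyl to (3,4-difluorophenyl)carbamoyl on an oxygen on an aromatic ring gives a number 11.1 percentage points lower from compound 2 to compound 3 (beyond the scatter) in this assay and is the first single-place change that can be read here. It shows that the small inhibition of compound 2 depends on what this oxygen carries, as it does not survive this replacement even though the entering group keeps a six-membered aromatic ring of carbon only while bringing in nitrogen, oxygen and fluorine. No measurement at hand gives a reason for this step.

The compounds shown leave open whether the loss follows from the carbamoyl link or from the two fluorine atoms, which an unsubstituted phenylcarbamoyl group on the same oxygen would separate. They also leave open how a smaller group, such as methyl or acetyl, would read at this place.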